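Swapping Methoxy for Chloro: Cytotoxicity Outlook

The source may hold more compounds than are shown below. What is called first, only, known or untested is meant among the compounds shown, and "the series" means these compounds.

Compound 1, `COc1cc(NC(=O)c2ccc(C#N)cc2)ccc1NS(C)(=O)=O`, in an ADME assay on RAW264.7 cells (Mus musculus) for cytotoxicity, read by MTT assay, with a stated time of 48 h (a higher number here means a weaker inhibitor, a lower number a stronger inhibitor), gives > 250000 nM, which is a limit of the assay and not a number.
Compound 2, `COc1cc(NC(=O)c2cccc(C(F)(F)F)c2)ccc1NS(C)(=O)=O`, in this assay gives 84800 nM.
Compound 3, `CS(=O)(=O)Nc1ccc(NC(=O)c2ccc(C#N)cc2)cc1Cl`, in this assay gives > 250000 nM, again a limit rather than a number.

Compound 2 is the only one of the three with a measured number, two values sitting at the limit of > 250000 nM in this assay, at which 2 of the 3 values shown sit. The difference between the core of compound 1 and that of compound 2 is not broken down here. Compound 1 and compound 3 differ by chloro in place of methoxy on an aromatic carbon, and that change gives a step that the two limits leave unreadable from compound 1 to compound 3. Compound 4, `CS(=O)(=O)Nc1ccc(NC(=O)c2cccc(C(F)(F)F)c2)cc1Cl`, not yet measured, arises from compound 2 by the same kind of change, (chloro in place of methoxy on an aromatic carbon). Among the compounds with values here, compound 4 is expected to be close to compound 2, since the only measured example of this change is unreadable, so the estimated step is a 1.2-fold higher number from compound 2 to compound 4 (0.07 log units; within the scatter). Compound 4 is therefore estimated at 100000 nM, between 40000 nM and 250000 nM.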

Compound 4, half-maximal inhibitory concentration: > 250000 nM
Compound 4 gave a limit, no number; the forecaster's own chance of this, stated with the estimate: 35%; middle value at least 2.5-fold (0.39 log units) from the limit.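

In this assay compound 4 gives > 250000 nM, a limit of the assay and not a number. With trifluoromethyl in place of nitrile on the other side of the amide, chloro in place of methoxy gives an at least 2.9-fold higher number from compound 2 to compound 4 (0.46 log units; beyond the scatter), so on this core the change moves the read-out towards weaker cytotoxicity, by an amount known only as a minimum. This is one readable example, and it does not show that the step carries over to another core, as the same change from compound 1 to compound 3 cannot be read: the limit of > 250000 nM in this assay, at which 3 of the 4 values shown sit.

The compounds shown leave open how an amine or a fluoro group would read in the place of chloro or methoxy. They also leave open whether a carboxylic acid in place of the methanesulfonamido group would give a measured number.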